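Replacing dimethylamino with methyl in compound 2

A few compounds are considered here, and "the series" means these few. Any claim that something is new, unique, unknown or untested is made for them only; others in the source may bear on it.

Compound 2 (`COc1cc(-c2nc(N(C)C)sc2-c2ccc(C(F)(F)F)cc2)cc(OC)c1OC`) gives > 10000 nM in a functional assay on HL-60 cells (Homo sapiens) for antiproliferative activity, read by MTT assay, with a stated time of 72 h (a higher number here means a weaker inhibitor, a lower number a stronger inhibitor), which is a limit of the assay and not a number. Its two measured neighbours do reach numbers. Compound 1 (`CNc1nc(-c2cc(OC)c(OC)c(OC)c2)c(-c2ccc(C(F)(F)F)cc2)s1`) gives 3170 nM, and compound 3 (`COc1ccc(-c2sc(N(C)C)nc2-c2cc(OC)c(OC)c(OC)c2)cc1`) gives 1890 nM.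

Compound 4 (`COc1cc(-c2nc(C)sc2-c2ccc(C(F)(F)F)cc2)cc(OC)c1OC`) puts methyl in place of dimethylamino on an aromatic carbon.

For the measured compounds named here, two measured steps bear on this change. The closer one changes the same group, with methyl in place of hydrogen on a nitrogen, and gives an at least 3.1-fold higher number from compound 1 to compound 2 (0.49 log units; beyond the scatter). So this site can move the number. The other step, methoxy in place of trifluoromethyl, gives an at least 5.2-fold lower number from compound 2 to compound 3 (0.72 log units; beyond the scatter). It shows that compound 2 can be improved, but it acts elsewhere and compound 4 keeps the trifluoromethyl.

A modest fall is therefore expected, and the result could still stop at the limit. The expected change is an at least 2.2-fold lower number from compound 2 to compound 4 (0.34 log units; beyond the scatter). For compound 4 the estimate is 4500 nM, with an expected range from 1200 nM to 17000 nM.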

Compound 4, half-maximal inhibitory concentration: > 10000 nM
Compound 4 ended at the assay's limit (the forecaster's own chance of this, stated with the estimate: 35%); middle value at least 2.2-fold (0.34 log units) from the limit.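

In this assay, the step from compound 2 to compound 4 cannot be read, because both compounds sit at a limit of the assay: the limit of > 10000 nM in this assay, at which 2 of the 4 values shown sit.

Taking away dimethylamino and putting methyl there therefore brings no measurable number back. Methyl in place of methylamino gives an at least 3.1-fold higher number from compound 1 to compound 4 (0.49 log units; beyond the scatter), so among the three groups shown at this position with the 4-(trifluoromethyl)phenyl group kept, only methylamino, in compound 1, gives a number rather than a limit.

Going by these compounds, it remains open whether a plain amine or a longer chain such as ethylamino at this position would give a lower number than compound 1. Also open, on these data alone, is whether methoxy in place of trifluoromethyl would bring compound 4 down from its limit, as it does for compound 2 in an at least 5.2-fold lower number from compound 2 to compound 3 (0.72 log units; beyond the scatter).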